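Swapping the aniline again on a quinazoline-like scaffold

A few compounds are considered here, and "the series" means these few. Any claim that something is new, unique, unknown or untested is made for them only; others in the source may bear on it.

Within the data shown here, compound 2, `COc1ccccc1Nc1ncnc2cc(OC)c(OCCCCC(=O)Nc3ccc(S(N)(=O)=O)cc3)cc12`, is the only compound here with a numerical result. In a functional assay on A549 cells (Homo sapiens) for antiproliferative activity, read by MTT assay, with a stated time of 72 h (a lower number here means a stronger inhibitor, a higher number a weaker inhibitor), compound 2 gives 24100 nM. Compound 1, `COc1cc2ncnc(Nc3ccc(OC(F)(F)F)cc3)c2cc1OCCCCC(=O)Nc1ccc(S(N)(=O)=O)cc1`, has only a limit of the assay: in this assay compound 1 gives > 40000 nM, which is a limit and not a number. Among the measured compounds shown here, the one measured step, an at least 1.6-fold lower number from compound 1 to compound 2 (0.22 log units; that floor lies within the scatter), therefore rests on the limit of > 40000 nM in this assay, at which 1 of the 2 values shown sits, and its size cannot be pinned down beyond its floor.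

Compound 3, `COc1cc2ncnc(Nc3ccc(C(F)(F)F)cc3)c2cc1OCCCCC(=O)Nc1ccc(S(N)(=O)=O)cc1`, differs from compound 2 in the group on the nitrogen on an aromatic ring: 4-(trifluoromethyl)phenyl in place of 2-methoxyphenyl on a nitrogen on an aromatic ring. This change moves back toward the kind of group carried by compound 1, a 4-substituted phenyl bearing fluorines, where the measured step from a 4-(trifluoromethoxy)phenyl to 2-methoxyphenyl only reached the floor of the scatter. The expectation for compound 3 is thus a step no larger than that floor, most likely in the direction of a higher number, estimated as a 1.7-fold higher number from compound 2 to compound 3 (0.22 log units; within the scatter). Compound 3 is expected to give about 40000 nM, within 15000 nM to 120000 nM, with a fair chance that only a limit is reported.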

Compound 3, half-maximal inhibitory concentration: 14800 nM
Beside the measured number, compound 3's estimate is 2.7-fold (0.43 log units) above it; the whole stated range lies above it.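

On the nitrogen on an aromatic ring, 4-(trifluoromethyl)phenyl in place of 2-methoxyphenyl gives a 1.6-fold lower number from compound 2 to compound 3 (0.21 log units; within the scatter) in this assay, so these two groups cannot be told apart in this test, even though they differ in the substituent they carry and in where its name places it on the phenyl ring. The clearer result comes from the comparison with compound 1: trifluoromethyl in place of trifluoromethoxy on an aromatic carbon gives an at least 2.7-fold lower number from compound 1 to compound 3 (0.43 log units; beyond the scatter), the only step among these three compounds printed as beyond the scatter, and it shows that this small exchange within the 4-substituted phenyl groups can be seen in the read-out. Its true size stays unknown, and the figure is only a floor, because compound 1 gives a limit and not a number: the limit of > 40000 nM in this assay, at which 1 of the 3 values shown sits.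

On these data alone, whether a plain phenyl or a 4-chlorophenyl on the same nitrogen would separate from these groups remains open. All three compounds also share the rest of the structure, so the effect of a shorter chain, or of a carboxylic acid in place of the sulfonamide, cannot be judged from them.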